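The compounds below may be only part of what the source reports. "The series", "measured", "known", "first", "only" and "open" are said of these compounds alone.

Compound 1 `C/C=C1/[C@H](O[C@@H]2O[C@H](COC(C)=O)[C@@H](OC(C)=O)[C@H](OC(C)=O)[C@H]2OC(C)=O)OC=C(C(=O)OC)[C@H]1CC(=O)OCCC1CCCCC1` and compound 2 `C/C=C1/[C@H](O[C@@H]2O[C@H](COC(C)=O)[C@@H](OC(C)=O)[C@H](OC(C)=O)[C@H]2OC(C)=O)OC=C(C(=O)OC)[C@H]1CC(=O)SCCC` share a core and differ in the group on a carbonyl carbon. In a functional assay on SK-BR-3 cells (Homo sapiens) for antiproliferative activity, read by MTT assay, with a stated time of 72 h (on this read-out higher numbers stand for weaker inhibition and lower numbers for stronger inhibition), compound 1 gives > 15000 nM as a limit of the assay, not a number. Compound 2 gives > 15000 nM and this too is a limit. All that is known so far is the limit of > 15000 nM in this assay, at which 2 of the 2 values shown sit, and nothing more.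

Compound 3 `C/C=C1/[C@H](O[C@@H]2O[C@H](COC(C)=O)[C@@H](OC(C)=O)[C@H](OC(C)=O)[C@H]2OC(C)=O)OC=C(C(=O)OC)[C@H]1CC(=O)OC` has not yet been measured. Set against compound 2, it carries methoxy in place of propylsulfanyl on a carbonyl carbon, a change counted as methoxy in place of propylsulfanyl on a carbonyl carbon in full. Going by the values given here, the only measured step that bears on this is a step that the two limits leave unreadable from compound 1 to compound 2 and it concerns a change on the same carbonyl carbon. It has no readable size to carry over, so neither direction is favoured. The expectation is that compound 3 also stays close to the limit in this assay and shows no step beyond the scatter. The estimate therefore means a step that the limit leaves unreadable from compound 2 to compound 3 as the expected step. For compound 3 the estimated value is 20000 nM with an expected range from 9000 nM to 40000 nM on repeated measurement.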

Compound 3, half-maximal inhibitory concentration: > 15000 nM
Compound 3 ended at the assay's limit; the forecaster's own chance of this, stated with the estimate: 80%; the middle value does not contradict the limit.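

No step among compound 1, compound 2 and compound 3 can be read in this assay, since all three end at a limit of the assay and not at a number: the limit of > 15000 nM in this assay, at which 3 of the 3 values shown sit.

From the compounds shown here alone, how far each compound lies past that limit, and whether the group on the carbonyl carbon alters the read-out at all, stays open.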